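A Simpler Aryl Group on the Urea Nitrogen

This account rests on a few compounds, and the source may have more. Where it says the series, first, only, none or still open, it means among the compounds named here.

Among the compounds with values here, compound 2 `O=C(Nc1cccc(CN2CCCC2)c1)Nc1ccc2ncnc(Nc3cccc(C(F)(F)F)c3)c2c1` gives 860 nM in a functional assay on A549 cells (Homo sapiens) for antiproliferative activity, read by MTT assay, with a stated time of 72 h (a lower number here means a stronger inhibitor, a higher number a weaker inhibitor), the lowest of the two numbers so far, while compound 1 `CCN(CC)Cc1ccc(NC(=O)Nc2ccc3ncnc(Nc4cccc(C(F)(F)F)c4)c3c2)cc1` gives 2070 nM. The step of a 2.4-fold lower number from compound 1 to compound 2 (0.38 log units; beyond the scatter) shows that exchanging the aryl group on the amide-type nitrogen moves the number modestly. Compound 3 `Cc1ccc(NC(=O)Nc2ccc3ncnc(Nc4cccc(C(F)(F)F)c4)c3c2)cc1` differs from compound 2 by 4-methylphenyl in place of 3-((pyrrolidin-1-yl)methyl)phenyl on an amide-type nitrogen. Within the data shown here, no measured step covers this exchange, so the only guide is the modest size of the one change seen at this position. A step of a 2.9-fold higher number from compound 2 to compound 3 (0.46 log units; beyond the scatter) toward a higher number is therefore expected. Compound 3 is estimated at 2500 nM, within 800 nM to 8000 nM.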

Compound 3, half-maximal inhibitory concentration: 4140 nM
For compound 3 the middle estimate is 1.7-fold (0.22 log units) below the measured one; the range from low to high includes it.
By their numbers in this assay, from the lowest: compound 2; then compounds 1 and 3 (each within the scatter of the next).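

A second exchange on the amide-type nitrogen in this assay also moves the number beyond the usual scatter: 4-methylphenyl in place of 3-((pyrrolidin-1-yl)methyl)phenyl gives a 4.8-fold higher number from compound 2 to compound 3 (0.68 log units; beyond the scatter). By contrast, hydrogen in place of diethylamino on the saturated chain carbon gives a 2.0-fold higher number from compound 1 to compound 3 (0.30 log units; within the scatter), so that exchange has no readable effect. Still open, from the compounds shown here alone, is what a morpholine ring or a carboxylic acid would do on this aryl group. No measurement at hand gives a reason for either step.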